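A few compounds are considered here, and "the series" means these few. Any claim that something is new, unique, unknown or untested is made for them only; others in the source may bear on it.

In an assay on membranes from brain for displacement of a labelled ligand from Sigma non-opioid intracellular receptor 1 (Cavia porcellus), read by scintillation counting, with a stated time of 120 min (on this read-out lower numbers stand for stronger inhibition and higher numbers for weaker inhibition), compound 1 `c1ccc([C@H]2CCC[C@@H](CCN3CCCC3)C2)cc1` gives 3.6 nM and compound 3 `c1ccc([C@H]2CCC[C@@H](CCN3CCN(c4ccccc4)CC3)C2)cc1` gives 16 nM. Compound 2 `NCC[C@@H]1CCC[C@H](c2ccccc2)C1` gives 167 nM, the highest number of the three, reached through the large step of a 46-fold higher number from compound 1 to compound 2 (1.67 log units; beyond the scatter). Compound 4 `NCC[C@H]1CCC[C@H](c2ccccc2)C1` differs from compound 2 as follows: the two compounds have the same atoms and bonds and differ only in configuration as drawn: 1 of 2 stereo elements differ; a stereocentre at a saturated ring carbon is drawn R in compound 2 and S in compound 4. Within the data shown here, no measured step alters a stereocentre: the one measured step, a 46-fold higher number from compound 1 to compound 2 (1.67 log units; beyond the scatter), exchanges a group rather than a configuration, so it gives no guide to the direction or size of this change. With nothing directly comparable in hand, the expected step of a 1.2-fold higher number from compound 2 to compound 4 (0.08 log units; within the scatter) is set near no change, while a shift either way beyond the scatter remains possible. Compound 4 is therefore estimated at 200 nM, within 50 nM to 800 nM.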

Compound 4, inhibition constant: 603 nM
For compound 4 the middle estimate is 3.0-fold (0.48 log units) below the measured one; low and high end bracket the measured number.
By their numbers in this assay, from the lowest: compound 1; then compound 3; then compound 2; then compound 4.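

In this assay the stereocentre at this saturated ring carbon matters by itself: drawing it S rather than R gives a 3.6-fold higher number from compound 2 to compound 4 (0.56 log units; beyond the scatter) and so moves the number beyond the scatter. The earlier compounds shown here showed only exchanges of the group on the chain, whereas here the atoms and bonds stay fixed. The step can therefore be traced to configuration alone, on this ground: the fact that compounds 2 and 4 differ only in the configuration as drawn.

From the compounds shown here alone, whether this change has a similar size with pyrrolidin-1-yl or 4-phenylpiperazin-1-yl on the chain stays open. So does its size with a dimethylamino group or a longer chain.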